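The source may report more compounds than this note shows. Statements on the series, on what has been measured and on what is new or still open speak of the compounds shown alone.

Working notes on the series. In an ADME assay, at pH 3 (on this read-out higher numbers stand for a longer-lived compound and lower numbers for a shorter-lived compound), compound 3 `COc1ccnc(C[S+]([O-])c2nc3cc(OC(F)(F)C(F)F)ccc3[nH]2)c1` gives 0.167 h. This lies within the scatter of both compound 1 `COc1ccnc(C[S+]([O-])c2nc3cc(OC(F)(F)C(F)F)ccc3[nH]2)c1OC` at 0.3 h and compound 2 `COc1cnc(C[S+]([O-])c2nc3cc(OC(F)(F)C(F)F)ccc3[nH]2)c(C)c1OC` at 0.333 h, so the three measured numbers do not separate.

The next compound is compound 4 `COc1ccnc(C[S+]([O-])c2nc3cc(OC(F)(F)C(F)F)ccc3[nH]2)c1C`, which has methyl in place of hydrogen on an aromatic carbon. The same change, cut one bond further out, reads 4-methoxypyridin-2-yl to 4-methoxy-3-methylpyridin-2-yl.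

Among the measured compounds shown here, only one measured single-place step bears on this: a 1.8-fold lower number from compound 1 to compound 3 (0.25 log units; within the scatter), with hydrogen in place of methoxy on the same aromatic carbon. That step stays within the scatter, so it gives only a weak hint on size and no firm direction. For the measured compounds named here, compound 2 differs from compound 3 in more than one place and adds no clean step. Going by the values given here, no measurement yet shows methyl on this carbon.

In this assay, no move beyond the scatter is therefore expected, and compound 4 is expected to fall among the three measured numbers. The expected change is a 1.5-fold higher number from compound 3 to compound 4 (0.18 log units; within the scatter). For compound 4 the estimated half-life is 0.25 h, with an expected range of 0.14 h to 0.42 h.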

Compound 4, half-life: 0.0833 h
Beside the measured number, compound 4's estimate is 3.0-fold (0.48 log units) above it; measured number below the stated range.
By their numbers in this assay, from the lowest: compounds 4, 3, 1 and 2 (each within the scatter of the next, the first and the last beyond it).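

In this assay, methyl on this carbon, the first group other than hydrogen or methoxy seen here, does not separate from hydrogen, with a 2.0-fold lower number from compound 3 to compound 4 (0.30 log units; within the scatter) as the step. Methyl in place of methoxy on the same carbon does pass the scatter, with a 3.6-fold lower number from compound 1 to compound 4 (0.56 log units; beyond the scatter) as the step, so the methoxy compound and the methyl compound can be told apart at this position even though hydrogen and methyl cannot. Hydrogen in place of methoxy now also passes the scatter once, with a 4.0-fold lower number from compound 2 to compound 4 (0.60 log units; beyond the scatter) as the step, yet the two readings of that change do not separate from each other: the same change on two cores in this assay, a 1.8-fold lower number (0.25 log units; within the scatter) from compound 1 to compound 3 and a 4.0-fold lower number (0.60 log units; beyond the scatter) from compound 2 to compound 4, 2.2-fold (0.35 log units) apart, within the scatter of two such steps.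

As far as these compounds go, whether an ethyl group or an amine on this carbon would fall with methyl or with methoxy stays open. From the compounds shown here alone, all four compounds also keep the same fluorinated ether chain on the shared core, so how these steps would read with a plain methoxy group in its place is unknown.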